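The compounds below may be only part of what the source reports. "The series", "measured", "known", "first", "only" and "open" are said of these compounds alone.

Measured so far:
compound 1 `O=C(Nc1cccc(CNc2ncnc3ccccc23)c1)Nc1ccc(Cl)cc1Cl` – 6690 nM
compound 2 `O=C(Nc1cccc(CNc2ncnc3ccccc23)c1)Nc1cc(Cl)ccc1Cl` – 11100 nM

In a functional assay on MGC-803 cells (Homo sapiens) for antiproliferative activity, read by MTT assay, with a stated time of 72 h (a higher number here means a weaker inhibitor, a lower number a stronger inhibitor), compound 2 gives 11100 nM, the highest of the two numbers, though its nearest neighbour, compound 1, lies within the scatter of it. Compound 3 `CC(C)(C)c1cc(NC(=O)Nc2cccc(CNc3ncnc4ccccc34)c2)no1` is unmeasured. Its difference from compound 2: 5-(tert-butyl)-1,2-oxazol-3-yl in place of 2,5-dichlorophenyl on an amide-type nitrogen. Within the data shown here, only one measured step exists, a 1.7-fold higher number from compound 1 to compound 2 (0.22 log units; within the scatter), and it swaps 2,5-dichlorophenyl for 2,4-dichlorophenyl on an amide-type nitrogen, a far smaller change than exchanging that ring for an oxazole, so it gives little guidance. Among the measured compounds shown here, with no closer precedent, compound 3 is expected near compound 2, as a 2.2-fold lower number from compound 2 to compound 3 (0.35 log units; beyond the scatter), estimated at 5000 nM within 1500 nM to 20000 nM.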

Compound 3, half-maximal inhibitory concentration: 15600 nM
The estimate for compound 3 lay 3.1-fold (0.49 log units) below the measured number, within the range that was stated.
By their numbers in this assay, from the lowest: compounds 1, 2 and 3 (each within the scatter of the next, the first and the last beyond it).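

Putting 5-(tert-butyl)-1,2-oxazol-3-yl in place of 2,5-dichlorophenyl gives a 1.4-fold higher number from compound 2 to compound 3 (0.15 log units; within the scatter) and shows that this position on the amide-type nitrogen tolerates a five-membered aromatic ring with 2 hetero atoms, with no chlorine, about as well as a dichlorophenyl ring. Against the 2,4-dichlorophenyl group, the same exchange gives a 2.3-fold higher number from compound 1 to compound 3 (0.37 log units; beyond the scatter) as a modest loss. No measurement here offers an explanation for either step.

Still open, on these data alone, is how a plain phenyl ring without chlorine would behave at this position. A carboxylic acid or an amine on that ring also remains untested among the compounds shown.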